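This account rests on a few compounds, and the source may have more. Where it says the series, first, only, none or still open, it means among the compounds named here.

Measured compounds:
- compound 1 `S=C(Nc1ccccc1)N1N=C(c2ccc(Cl)cc2)CC1c1ccc2c(c1)OCCO2`: 195000 nM
- compound 2 `FC(F)(F)c1ccc(C2=NN(C(=S)Nc3ccccc3)C(c3ccc4c(c3)OCCO4)C2)cc1`: 43500 nM
- compound 3 `S=C(Nc1ccccc1)N1N=C(c2ccccc2Br)CC1c1ccc2c(c1)OCCO2`: a limit only
- compound 4 `S=C(Nc1ccccc1)N1N=C(c2ccc(Cl)c(Cl)c2)CC1c1ccc2c(c1)OCCO2`: not yet measured

In a functional assay on A-375 cells (Homo sapiens) for antiproliferative activity, read by MTT assay, with a stated time of 48 h (on this read-out higher numbers stand for weaker inhibition of growth and lower numbers for stronger inhibition of growth), compound 3 reaches only a limit, > 200000 nM. That value is the limit of > 200000 nM in this assay, at which 1 of the 3 values shown sits, so compound 3 has no number of its own. Compound 4 differs from compound 3 by 3,4-dichlorophenyl in place of 2-bromophenyl on a carbon with a double bond to nitrogen. Among the measured compounds shown here, two measured steps bear on this exchange: an at least 1.0-fold higher number from compound 1 to compound 3 (0.01 log units; that floor lies within the scatter) and an at least 4.5-fold higher number from compound 2 to compound 3 (0.66 log units; beyond the scatter). Read in reverse, replacing 2-bromophenyl with a phenyl bearing substituents elsewhere gave a lower or unchanged number in this assay. For compound 4 the expected step is therefore an at least 2.5-fold lower number from compound 3 to compound 4 (0.39 log units; beyond the scatter), a downward move. Compound 4 is estimated at 80000 nM, with a range from 20000 nM to 200000 nM.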

Compound 4, concentration for 50% growth inhibition: 41900 nM
Beside the measured number, compound 4's estimate is 1.9-fold (0.28 log units) above it; low and high end bracket the measured number.
By their numbers in this assay, from the lowest: compounds 4 and 2 (each within the scatter of the next); then compound 1. At a limit, above all of these: compound 3.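

In this assay, adding a second chlorine to the 4-chlorophenyl group gives a 4.7-fold lower number from compound 1 to compound 4 (0.67 log units; beyond the scatter), so this aryl group on the carbon with a double bond to nitrogen responds to an added substituent as well as to an exchanged one. Exchanging 4-(trifluoromethyl)phenyl for 3,4-dichlorophenyl gives a 1.0-fold lower number from compound 2 to compound 4 (0.02 log units; within the scatter), so these two groups cannot be told apart here. Compound 3 stands only at a limit, so this exchange reads as a floor: an at least 4.7-fold lower number from compound 3 to compound 4 (0.67 log units; beyond the scatter).

As far as these compounds go, whether that limit goes with bromine itself or with where it sits on the ring stays open. So does the effect of an amine or a carboxylic acid on this ring.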